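The compounds below may be only part of what the source reports. "The series", "measured", "known", "first", "only" and "open" are said of these compounds alone.

Compound 1 `O=C1COc2ccc(-c3cnc(Cl)c(NS(=O)(=O)c4ccc(F)cc4)c3)cc2N1c1ccccc1` — 14700 nM
Compound 2 `O=C1COc2ccc(-c3cnc4ccccc4c3)cc2N1C1CCCCC1` — > 40000 nM

Of the compounds shown here, two have been measured in a functional assay on A549 cells (Homo sapiens) for antiproliferative activity, read by MTT assay, with a stated time of 72 h; a lower number here means a stronger inhibitor, a higher number a weaker inhibitor. Among the compounds with values here, compound 1 gives 14700 nM in this assay, which is the only plain number so far. Compound 2 reaches only a limit of the assay, reported as > 40000 nM, so it carries no number of its own. Within the data shown here, compound 1 therefore stands as the sole anchor, and it sits a long way from strong inhibition; the other entry, (the limit of > 40000 nM in this assay, at which 1 of the 2 values shown sits), tells only that compound 2 lies at the edge of what the assay can report.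

Compound 3 `CC(C)N1C(=O)COc2ccc(-c3cnc(Cl)c(NS(=O)(=O)c4ccc(F)cc4)c3)cc21` has not yet been measured. It differs from compound 1 in one place: isopropyl in place of phenyl on an amide-type nitrogen in a ring. Among the measured compounds shown here, no measured pair shows what such a change does here, so the size of the step from compound 1 to compound 3 cannot be read from the data, and any expectation rests on compound 1 alone. The step of a 1.4-fold higher number from compound 1 to compound 3 (0.13 log units; within the scatter) is expected to stay within the usual scatter, with no clear direction. Compound 3 is estimated to give 20000 nM, in a range from 6000 nM to 60000 nM.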

Compound 3, half-maximal inhibitory concentration: 5100 nM
The estimate for compound 3 lay 3.9-fold (0.59 log units) above the measured number; measured number below the stated range.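

The earlier compounds shown here showed no measured change at the amide-type nitrogen in a ring, and now there is one: in this assay, isopropyl in place of phenyl gives a 2.9-fold lower number from compound 1 to compound 3 (0.46 log units; beyond the scatter), with the rest of the molecule unchanged. This position therefore responds to the group it carries, and the six-membered aromatic ring of phenyl is not needed there for the activity seen, since isopropyl, with no ring and fewer heavy atoms, gives the lower number in this pair. Nothing measured here accounts for the change, so the pair gives its size and direction but no cause.

On these data alone, a single pair cannot separate losing the ring from shrinking the group, so it remains open whether a methyl, a longer chain such as n-butyl, or a cyclopropyl ring on this nitrogen would lower the number further or raise it again. Also open, as far as these compounds go, is how a group carrying an amine or a carboxylic acid would behave at this position, and whether the same step would recur on a different core.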